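A few compounds are considered here, and "the series" means these few. Any claim that something is new, unique, unknown or untested is made for them only; others in the source may bear on it.

Compound 1 `OC[C@H]1O[C@@H](n2cnc3c(NCc4ccc(F)cc4)ncnc32)[C@H](O)[C@@H]1O` gives the lowest number of the three measured compounds in a functional assay on HL-60 cells (Homo sapiens) for antiproliferative activity, with a stated time of 72 h (on this read-out lower numbers stand for stronger inhibition and higher numbers for weaker inhibition), where compound 1 gives 1200 nM. Compound 2 `COc1cccc(CNc2ncnc3c2ncn3[C@@H]2O[C@H](CO)[C@@H](O)[C@H]2O)c1` gives 4900 nM in this assay, and compound 3 `COc1ccc(CNc2ncnc3c2ncn3[C@@H]2O[C@H](CO)[C@@H](O)[C@H]2O)c(OC)c1` gives 39000 nM. Both measured steps away from compound 1 weaken the read-out: a 4.1-fold higher number from compound 1 to compound 2 (0.61 log units; beyond the scatter) and a 33-fold higher number from compound 1 to compound 3 (1.51 log units; beyond the scatter), and between those two compounds there is an 8.0-fold higher number from compound 2 to compound 3 (0.90 log units; beyond the scatter).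

Compound 4 `OC[C@H]1O[C@@H](n2cnc3c(NCc4c(F)ccc(F)c4F)ncnc32)[C@H](O)[C@@H]1O` keeps the shared core of compound 1 and differs from it in one place: 2,3,6-trifluorophenyl in place of 4-fluorophenyl on a saturated chain carbon bound to a nitrogen on an aromatic ring. For the measured compounds named here, no measured step exchanges one fluorinated ring for another; the steps from compound 1 to compound 2 and from compound 1 to compound 3 instead replace the 4-fluorophenyl with methoxy-bearing rings and give modest to large weakening. They therefore bear only loosely on the change to compound 4, and they show that moving away from the 4-fluorophenyl has so far cost potency in this assay. For compound 4 a small step is expected in this assay, most likely toward a higher number but possibly within the scatter, amounting to a 1.5-fold higher number from compound 1 to compound 4 (0.18 log units; within the scatter). Compound 4 is thus estimated at 1800 nM in this assay, with a range from 500 nM to 6500 nM.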

Compound 4, half-maximal inhibitory concentration: 13000 nM
Beside the measured number, compound 4's estimate is 7.2-fold (0.86 log units) below it, outside the stated range (above it).
By their numbers in this assay, from the lowest: compound 1; then compound 2; then compound 4; then compound 3.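

In this assay, swapping one fluorinated ring for another at this place is not a neutral change: the 2,3,6-trifluorophenyl group gives an 11-fold higher number from compound 1 to compound 4 (1.03 log units; beyond the scatter) and thus shows that fluorine on the ring does not by itself preserve the number of compound 1. Compared with the methoxy-bearing rings, the new ring gives a 2.7-fold higher number from compound 2 to compound 4 (0.42 log units; beyond the scatter) and a 3.0-fold lower number from compound 3 to compound 4 (0.48 log units; beyond the scatter) in this assay, so the order does not divide into fluorinated rings on one side and methoxy-bearing rings on the other, while compound 1 keeps the lowest number of the four. The data at hand offer no explanation for these differences.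

The compounds shown leave open whether the higher number of compound 4 goes with the count of fluorine atoms or with where they sit on the ring, a question that a difluorophenyl group could help to separate. They also leave open whether the 4-fluorophenyl result depends on fluorine at all, which a plain phenyl or a 4-chlorophenyl group at this place would test.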